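Moving away from the 3-nitrophenyl group of compound 3

The source may report more compounds than this note shows. Statements on the series, on what has been measured and on what is new or still open speak of the compounds shown alone.

In a functional assay on MCF7 cells (Homo sapiens) for antiproliferative activity, read by MTT assay, with a stated time of 72 h (a higher number here means a weaker inhibitor, a lower number a stronger inhibitor), compound 1 `CCOc1ccc(-c2ccc3ncn(-c4cc(OC)c(OC)c(OC)c4)c3c2)cc1` gives 1710 nM and compound 2 `COc1cc(-n2cnc3ccc(-c4ccc(C(C)=O)cc4)cc32)cc(OC)c1OC` gives 1540 nM. The step between them, a 1.1-fold lower number from compound 1 to compound 2 (0.05 log units; within the scatter), shows no separation. Compound 3 `COc1cc(-n2cnc3ccc(-c4cccc([N+](=O)[O-])c4)cc32)cc(OC)c1OC` gives 4560 nM, the weakest of the three. Two measured steps lead to it: a 2.7-fold higher number from compound 1 to compound 3 (0.43 log units; beyond the scatter) and a 3.0-fold higher number from compound 2 to compound 3 (0.47 log units; beyond the scatter). Both are modest, and both introduce the 3-nitrophenyl group.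

Compound 4 `COc1cc(-n2cnc3ccc(-c4ccc(C)cc4)cc32)cc(OC)c1OC` removes that group: 4-methylphenyl in place of 3-nitrophenyl on an aromatic carbon. This is 4-methylphenyl in place of 3-nitrophenyl on an aromatic carbon. For the measured compounds named here, no compound with the 4-methylphenyl group has been measured, so the expectation rests on only those two steps. Run in reverse, they suggest a modest step towards a lower number in this assay, of similar size to the two measured ones. That would return the series to the level of compound 1 and compound 2. The estimated change is a 2.5-fold lower number from compound 3 to compound 4 (0.40 log units; beyond the scatter). For compound 4 the expected value is 1800 nM, with an estimated range of 850 nM to 3800 nM.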

Compound 4, half-maximal inhibitory concentration: 110 nM
The estimate for compound 4 lay 16-fold (1.21 log units) above the measured number; the whole stated range lies above it.
By their numbers in this assay, from the lowest: compound 4; then compounds 2 and 1 (each within the scatter of the next); then compound 3.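

In this assay, for the compounds shown here, the group on this aromatic carbon can move the number much further than the earlier compounds suggested: a 41-fold lower number from compound 3 to compound 4 (1.62 log units; beyond the scatter), whereas the earlier steps here were modest or within the scatter. Leaving the 3-nitrophenyl group does not account for the whole gain, since the other two comparisons are also large: a 14-fold lower number from compound 2 to compound 4 (1.15 log units; beyond the scatter), and a 16-fold lower number from compound 1 to compound 4 (1.19 log units; beyond the scatter). Among the three groups carried on the 4-position of this phenyl ring, methyl therefore stands apart from acetyl and ethoxy, which could not be separated from each other.

Nothing available here explains the size of this difference. On these data alone, it remains open how narrow the preference for methyl is, and an ethyl group, a chlorine atom or an amine in its place would test that.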